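This account rests on a few compounds, and the source may have more. Where it says the series, first, only, none or still open, it means among the compounds named here.

Measured in a physicochemical assay for pharmacokinetics, at pH 8; a lower number here means that the compound disappears faster, a higher number that the compound lasts longer:
Compound 1 `O=C(Sc1cccnc1C(=O)O)c1ccccc1Cl`: 75.8 h
Compound 2 `O=C(Sc1cccnc1C(=O)O)c1ccc(Cl)cc1`: 26.6 h

Of these two numbers, compound 2 has the lower one, and the gap to compound 1 lies beyond the usual scatter. Compound 3 `Cc1ccc(C(=O)Sc2cccnc2C(=O)O)cc1` is compound 2 with one change: methyl in place of chloro on an aromatic carbon, para to a large group (methyl in place of chloro on an aromatic carbon). Among the compounds with values here, no measured pair shows this swap, so there is little to go on. In this assay, a small rise that stays within the scatter is expected. The estimated step is a 1.6-fold higher number from compound 2 to compound 3 (0.20 log units; within the scatter). Compound 3 is expected at 42 h, within an estimated range of 24 h to 75 h.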

Compound 3, half-life: 80.1 h
Estimate against measurement, compound 3: 1.9-fold (0.28 log units) below; measured number outside the range, above it.
By their numbers in this assay, from the lowest: compound 2; then compounds 1 and 3 (each within the scatter of the next).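

At this position, para to a large group, methyl in place of chloro is no small change in this assay and gives a 3.0-fold higher number from compound 2 to compound 3 (0.48 log units; beyond the scatter) on a single swap, with the rest of the structure untouched. The step lies beyond the usual scatter, so this place on the ring clearly affects how long the compound lasts. Within the data shown here, nothing measured so far explains the rise. Still open, on these data alone, is how other groups at this same place would behave, such as a fluoro, a methoxy or an amine, and whether a longer chain such as ethyl would go further than methyl.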